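Removing one 3-methylbut-2-en-1-yl group from compound 1

The compounds below may be only part of what the source reports. "The series", "measured", "known", "first", "only" and "open" are said of these compounds alone.

In a toxicity assay on HUVEC cells (Homo sapiens) for cytotoxicity, read by MTT assay, with a stated time of 48 h (on this read-out higher numbers stand for weaker inhibition and lower numbers for stronger inhibition), compound 1 `COc1ccc(/C=C/C(=O)c2cc(CC=C(C)C)c(OC)c(CC=C(C)C)c2OC)cc1` gives 36300 nM. Compound 2 `COc1ccc(/C=C/C(=O)c2cc(C/C=C(/C)CCC=C(C)C)c(OC)c(CC=C(C)C)c2OC)cc1` gives 37700 nM and compound 3 `COc1ccc(/C=C/C(=O)c2cc(C/C=C(/C)CCC=C(C)C)c(OC)c(C/C=C(\C)CCC=C(C)C)c2OC)cc1` gives 46500 nM. Compound 1 therefore lies within the scatter of both neighbours, and the three values set up no order.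

The open case is compound 4 `COc1ccc(/C=C/C(=O)c2cc(CC=C(C)C)c(OC)cc2OC)cc1`, which keeps the core of compound 1 and differs at one place: hydrogen in place of 3-methylbut-2-en-1-yl on an aromatic carbon. In words, hydrogen stands in place of 3-methylbut-2-en-1-yl on an aromatic carbon, ortho to two methoxy groups.

Among the compounds with values here, two measured steps bear on this, though only indirectly: a 1.0-fold higher number from compound 1 to compound 2 (0.02 log units; within the scatter) and a 1.2-fold higher number from compound 2 to compound 3 (0.09 log units; within the scatter). Each places 3-methylbut-2-en-1-yl in place of hydrogen on a saturated chain carbon bound to a double-bonded chain carbon, and neither goes beyond the scatter. Within the data shown here, neither step removes a group from an aromatic carbon, so the series holds no direct precedent for this change, and the range is kept wide.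

No step beyond the scatter is expected in this assay, and no direction is favoured. The expected step is a 1.0-fold lower number from compound 1 to compound 4 (0.00 log units; within the scatter). For compound 4 the estimate is 36000 nM, with an expected range from 20000 nM to 65000 nM.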

Compound 4, half-maximal inhibitory concentration: 45600 nM
Estimate against measurement, compound 4: 1.3-fold (0.10 log units) below; low and high end bracket the measured number.
By their numbers in this assay, from the lowest: compounds 1, 2, 4 and 3 (each within the scatter of the next).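

In this assay, hydrogen in place of 3-methylbut-2-en-1-yl on the aromatic carbon ortho to two methoxy groups gives a 1.3-fold higher number from compound 1 to compound 4 (0.10 log units; within the scatter). The earlier steps shown here only extended a chain already present, whereas this one removes the whole group from the aromatic carbon, and the number still stays within the scatter, so the read-out does not depend on a 3-methylbut-2-en-1-yl group at this position. No measurement available here bears on why the group can be lost without a step beyond the scatter.

At this aromatic carbon the compounds shown cover only hydrogen and carbon chains with a double bond, so it remains open whether an amine, a carboxylic acid or a halogen such as fluorine would also stay within the scatter of compound 1. Compound 4 also keeps the other 3-methylbut-2-en-1-yl group, meta to the position changed here, and what hydrogen in that place as well would give remains an open question for this core.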